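Acyl thioureas on a diaryl pyrazole: dropping the methoxy

The source may report more compounds than this note shows. Statements on the series, on what has been measured and on what is new or still open speak of the compounds shown alone.

Measured so far in a functional assay on NCI-H460 cells (Homo sapiens) for inhibition, read by CCK-8 assay, with a stated time of 48 h; a higher number here means a weaker inhibitor, a lower number a stronger inhibitor:
- compound 1 `Cc1ccc(NC(=S)NC(=O)c2cn(-c3ccccc3)nc2-c2ccccc2)cc1`: 3960 nM
- compound 2 `COc1ccc(-c2nn(-c3ccccc3)cc2C(=O)NC(=S)Nc2ccc(Cl)cc2)cc1`: 3010 nM

Compound 2 holds the lowest of the two numbers in this assay, but its nearest neighbour, compound 1, sits only slightly higher and within the scatter, so no order between the two can be read. Compound 1 and compound 2 differ in two places at once, so their values show only that both sit in the same range.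

Compound 3 `O=C(NC(=S)Nc1ccc(Cl)cc1)c1cn(-c2ccccc2)nc1-c1ccccc1` is the next point: hydrogen in place of methoxy on an aromatic carbon, with the rest of compound 2 kept. Going by the values given here, no single-change step has been measured, so there is no reference for the size of such a removal here. Given that the two measured compounds lie within the scatter of each other despite two differences, the expectation for compound 3 is a step of about a 1.2-fold higher number from compound 2 to compound 3 (0.07 log units; within the scatter), not beyond the scatter in either direction. Compound 3 is thus estimated at 3500 nM in this assay, with a range from 1500 nM to 8500 nM.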

Compound 3, half-maximal inhibitory concentration: 4020 nM
Compound 3: the middle estimate sits 1.1-fold (0.06 log units) below what was measured, and the stated range covers the measured number.
By their numbers in this assay, from the lowest: compounds 2, 1 and 3 (each within the scatter of the next).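

In this assay, going by these compounds alone, the change 4-methoxyphenyl to phenyl gives a 1.3-fold higher number from compound 2 to compound 3 (0.13 log units; within the scatter) and is the first single-change reading: the methoxy on this aromatic carbon, para to a large group, has no effect that can be told from the scatter. The second single change, chloro in place of methyl on an aromatic carbon, gives a 1.0-fold higher number from compound 1 to compound 3 (0.01 log units; within the scatter) and likewise cannot be told from the scatter. Each place therefore accepts its exchange without a readable shift, though this holds only for these three compounds and these groups.

Going by these compounds, whether an amine or a carboxylic acid in place of the methoxy, or a longer chain in place of the chloro, would take the number beyond the scatter remains open. With all three compounds in one range, the series does not yet show which part of the shared structure governs the value in this assay at all.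

No measurement at hand bears on why these exchanges leave the number within the scatter.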